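Branching the Chain on the Amide Nitrogen

The source may hold more compounds than are shown below. What is called first, only, known or untested is meant among the compounds shown, and "the series" means these compounds.

Two compounds of the series have numbers. Compound 1 `CCN(C(=O)c1c(O)c2c(F)cccc2n(C)c1=O)c1ccccc1` in a functional assay on the whole organism for inhibition, with Mus musculus as the target, at a dose of 1 mg/kg by the oral route (a higher number here means more inhibition at the dose given (going by the name of the read-out), a lower number less inhibition), gives 60%. Compound 2 `CCCN(C(=O)c1c(O)c2c(Cl)cccc2n(C)c1=O)c1ccccc1` in this assay gives 94%, the higher of the two, and its distance from compound 1 lies beyond the scatter. Compound 3 `CC(C)N(C(=O)c1c(O)c2c(Cl)cccc2n(C)c1=O)c1ccccc1` differs from compound 2 only as isopropyl in place of propyl on an amide-type nitrogen. For the measured compounds named here, no measured pair shows this change, so its size is not known from the data. Compound 3 is expected to stay close to compound 2, with a step of a number 12 percentage points lower from compound 2 to compound 3 (beyond the scatter) expected to be small, downward or none beyond the scatter. The estimate for compound 3 is 82%, between 55% and 98%.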

Compound 3, a percentage reported as inhibition, in the whole organism at one dose (the size of the read-out at that dose, not a potency): 54%
For compound 3 the middle estimate is 28 percentage points above the measured one; measured number outside the range, below it.
By their numbers in this assay, from the lowest: compounds 3 and 1 (each within the scatter of the next); then compound 2.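

In this assay isopropyl in place of propyl on an amide-type nitrogen gives a number 40 percentage points lower from compound 2 to compound 3 (beyond the scatter) with no change in the chain's carbon count, so the response at this position depends on the chain's branching as well as its size. The earlier compounds shown here, both with unbranched chains, could not show this. Nothing available accounts for the size of this step.

Still open, from the compounds shown here alone, is whether a butyl chain or a cyclopropyl ring on this nitrogen would stay near compound 2 or fall towards compound 3. The separate contributions of chain and halogen also remain unresolved, since compounds 1 and 2 differ in both.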